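The source may report more compounds than this note shows. Statements on the series, on what has been measured and on what is new or still open speak of the compounds shown alone.

Working notes on the series. Compound 2 `CC(C)C(=O)OCOC(=O)N1CCN(C(=O)c2nc(Nc3cc(C4CC4)[nH]n3)c3cc(Cl)ccc3n2)C[C@H]1C` gives 14% in an ADME assay on S9 fraction from liver (Rattus norvegicus), read by LC-MS, with a stated time of 60 min, at 37 degrees C (a lower number here means that less of the compound is left, a higher number that more of the compound is left), the lowest of the three numbers obtained so far. Compound 1 `CC(C)COC(=O)N1CCN(C(=O)c2nc(Nc3cc(C4CC4)[nH]n3)c3cc(Cl)ccc3n2)C[C@H]1C` gives 61.1% in this assay, and compound 3 `CCCCCOC(=O)N1CCN(C(=O)c2nc(Nc3cc(C4CC4)[nH]n3)c3cc(Cl)ccc3n2)C[C@H]1C` gives 63.9%. The two measured steps that touch compound 2 are both large: a number 47.1 percentage points lower from compound 1 to compound 2 (beyond the scatter) and a number 49.9 percentage points higher from compound 2 to compound 3 (beyond the scatter). The (isopropylcarbonyl)oxy group on a saturated chain carbon bound to an oxygen next to a carbonyl group thus goes with the low number, whereas a number 2.8 percentage points higher from compound 1 to compound 3 (within the scatter) stays within the scatter. Compound 4 `COC(=O)N1CCN(C(=O)c2nc(Nc3cc(C4CC4)[nH]n3)c3cc(Cl)ccc3n2)C[C@H]1C` is the next member to be run. Its change from compound 2 is hydrogen in place of (isopropylcarbonyl)oxy on a saturated chain carbon bound to an oxygen next to a carbonyl group; cut one bond further out, the same difference reads methoxycarbonyl for (((isopropylcarbonyl)oxy)methoxy)carbonyl. Both large steps bear directly on this change: each removes or adds the same group at the same place, and removing it gave the high numbers of compound 1 and compound 3. A large rise in this assay is therefore expected, of roughly a number 48 percentage points higher from compound 2 to compound 4 (beyond the scatter). Compound 4 is expected to land near the two higher numbers of the series. Compound 4 is estimated at 62% in this assay, within 45% to 78%.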

Compound 4, percent of the compound remaining: 34.2%
The estimate for compound 4 lay 27.8 percentage points above the measured number; measured number below the stated range.
By their numbers in this assay, from the lowest: compound 2; then compound 4; then compounds 1 and 3 (each within the scatter of the next).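

The (isopropylcarbonyl)oxy group does not account for the whole gap at this position: taking it away to leave hydrogen gives only a modest gain (a number 20.2 percentage points higher from compound 2 to compound 4 (beyond the scatter)) in this assay, and compound 4 does not join compounds 1 and 3. Hydrogen on the saturated chain carbon bound to an oxygen next to a carbonyl group also separates from the two alkyl groups, with a modest fall for isopropyl (a number 26.9 percentage points lower from compound 1 to compound 4 (beyond the scatter)) and for butyl (a number 29.7 percentage points lower from compound 3 to compound 4 (beyond the scatter)), although isopropyl and butyl themselves remain within the scatter of each other. This position therefore has two distinct effects on the number among the four compounds: the ester-bearing compound 2 stands lowest, but the bare methoxycarbonyl compound 4 also stands apart from the isobutyl and pentyl carbamates, and nothing at hand explains either difference.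

The compounds shown leave open whether an ethyl or propyl group at this place would fall with compound 4 or with compounds 1 and 3, and so where along the chain the number changes. They also leave open how an amine or a carboxylic acid at the end of such a chain would read in this assay, and which part of each molecule is lost during the incubation.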